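The source may report more compounds than this note shows. Statements on the series, on what has been measured and on what is new or still open speak of the compounds shown alone.

Measured so far in a functional assay on PC-3 cells (Homo sapiens) for cytotoxicity, read by WST assay, with a stated time of 48 h; on this read-out higher numbers stand for weaker inhibition and lower numbers for stronger inhibition:
compound 1 `COc1ccc2c(/C=C(\C#N)C(=O)c3c[nH]c4cc(F)ccc34)c[nH]c2c1` gives 21400 nM
compound 2 `COc1ccc2c(/C=C(\C#N)C(=O)c3c[nH]c4cc(OC)ccc34)c[nH]c2c1` gives 27000 nM

Among the measured compounds shown here, compound 1 stands level with compound 2, the only other measured compound, as their values lie within the scatter of each other. Still unmeasured is compound 3 `N#C/C(=C\c1c[nH]c2cc(F)ccc12)C(=O)c1c[nH]c2cc(F)ccc12` which carries fluoro in place of methoxy on an aromatic carbon, a difference from compound 1 counted as fluoro in place of methoxy on an aromatic carbon on a six-membered aromatic ring of carbon only. For the measured compounds named here, one measured step bears on this, a 1.3-fold higher number from compound 1 to compound 2 (0.10 log units; within the scatter) with the same two groups exchanged the other way round at another aromatic carbon. Going by the values given here, with only that step to go on, no change beyond the scatter is expected in this assay and no direction can be favoured. The estimated step is a 1.1-fold lower number from compound 1 to compound 3 (0.03 log units; within the scatter) and stays within the scatter. Compound 3 is expected at 20000 nM with 9000 nM to 45000 nM as its estimated range.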

Compound 3, half-maximal inhibitory concentration: > 50000 nM
Compound 3 gave a limit, no number; the forecaster's own chance of this, stated with the estimate: 15%; middle value at least 2.5-fold (0.39 log units) away from the limit.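

In this assay, exchanging methoxy for fluoro is not neutral at every aromatic carbon: at this position it gives an at least 2.3-fold higher number from compound 1 to compound 3 (0.36 log units; beyond the scatter), whereas the same two groups exchanged the other way round at another aromatic carbon gave a 1.3-fold higher number from compound 1 to compound 2 (0.10 log units; within the scatter). The two positions therefore do not behave alike, and only at this one does the exchange move the result beyond the scatter, with methoxy carrying the lower number. As far as these compounds go, compound 3 gave a limit and not a number, so the full size of this step stays unknown: the limit of > 50000 nM in this assay, at which 1 of the 3 values shown sits.

The compounds shown leave open whether a hydroxyl, an amine or a longer chain such as ethoxy at this position would stay level with the methoxy of compound 1. They also leave open how a plain hydrogen there would compare.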